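The compounds below may be only part of what the source reports. "The series", "measured", "known", "first", "only" and "open" are said of these compounds alone.

In a functional assay on MCF7 cells (Homo sapiens) for cytotoxicity, read by MTT assay, with a stated time of 72 h (a higher number here means a weaker inhibitor, a lower number a stronger inhibitor), three compounds of a shared core have been measured. Compound 1 `O=C1c2c[n+]([O-])c3ccccc3c2C(=O)c2c1c1ccccc1n2CCCCn1ccnc1` gives 130 nM, compound 2 `O=C1c2c[n+]([O-])c3ccccc3c2C(=O)c2c1c1ccccc1n2CCN1CCCC1` gives 320 nM, and compound 3 `CC1(C)O[C@@H](CO)[C@H](Cn2cc(Cn3c4c(c5ccccc53)C(=O)c3c[n+]([O-])c5ccccc5c3C4=O)nn2)O1` gives 690 nM, the highest of the three numbers; its nearest neighbour is compound 2 and its furthest is compound 1. Among the compounds with values here, the one measured step between neighbours, a 2.5-fold higher number from compound 1 to compound 2 (0.39 log units; beyond the scatter), concerns a substituent on a chain carbon and does not touch the group that is changed here.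

Compound 4 `O=C1c2c[n+]([O-])c3ccccc3c2C(=O)c2c1c1ccccc1n2Cc1cn(C[C@@H](O)CO)nn1` differs from compound 3 in one place: 1,2-dihydroxyethyl in place of 5-(hydroxymethyl)-2,2-dimethyl-1,3-dioxolan-4-yl on a saturated chain carbon bound to an aromatic nitrogen. Within the data shown here, no measured step bears on this change, since both compound 1 and compound 2 carry different chains and the step of a 2.5-fold higher number from compound 1 to compound 2 (0.39 log units; beyond the scatter) exchanges other groups. The expectation for compound 4 in this assay therefore rests on compound 3 alone, and the estimated step of a 1.2-fold lower number from compound 3 to compound 4 (0.06 log units; within the scatter) is expected to be small, with no firm direction. Compound 4 is estimated at 600 nM, within a range from 250 nM to 1500 nM.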

Compound 4, half-maximal inhibitory concentration: 600 nM
The estimate for compound 4 equals the measured number at the digits printed, within the range that was stated.
By their numbers in this assay, from the lowest: compound 1; then compounds 2, 4 and 3 (each within the scatter of the next, the first and the last beyond it).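

In this assay the change from 5-(hydroxymethyl)-2,2-dimethyl-1,3-dioxolan-4-yl to 1,2-dihydroxyethyl on a saturated chain carbon bound to an aromatic nitrogen gives a 1.2-fold lower number from compound 3 to compound 4 (0.06 log units; within the scatter), so at this place the five-membered non-aromatic ring and one of the two defined stereocentres can go without a change beyond the scatter. The new 1-(2,3-dihydroxypropyl)-1H-1,2,3-triazol-4-yl chain also stands within the scatter of the (pyrrolidin-1-yl)methyl chain, with a 1.9-fold higher number from compound 2 to compound 4 (0.27 log units; within the scatter), whereas a 4.6-fold higher number from compound 1 to compound 4 (0.66 log units; beyond the scatter) shows a real gap to the 3-(1H-imidazol-1-yl)propyl chain. Nothing available explains these readings.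

The compounds shown leave open whether a carboxylic acid or a primary amine in place of 1,2-dihydroxyethyl would read the same. They also leave open whether the opposite configuration at its stereocentre would change the number.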